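Methoxy in Place of Methyl: An Estimate for Compound 4

This account rests on a few compounds, and the source may have more. Where it says the series, first, only, none or still open, it means among the compounds named here.

Three compounds have been measured in a functional assay on A549 cells (Homo sapiens) for inhibition, read by MTT assay, with a stated time of 72 h; a higher number here means a weaker inhibitor, a lower number a stronger inhibitor:

compound 1, `Cc1ccccc1NC(=O)CCC(=O)OCCCCCCSc1ccc([N+](=O)[O-])c2nonc12`, gives 4200 nM
compound 2, `COc1ccccc1NC(=O)CCC(=O)OCCCCCCSc1ccc([N+](=O)[O-])c2nonc12`, gives 1870 nM
compound 3, `Cc1ccc(NC(=O)CCC(=O)OCCCCCCSc2ccc([N+](=O)[O-])c3nonc23)cc1`, gives 5240 nM

Compound 4, `COc1ccc(NC(=O)CCC(=O)OCCCCCCSc2ccc([N+](=O)[O-])c3nonc23)cc1`, has not yet been measured. It differs from compound 3 by methoxy in place of methyl on an aromatic carbon. The same change has already been made once among the measured compounds, from compound 1 to compound 2, where it reads methoxy in place of methyl on an aromatic carbon and gave a step of a 2.2-fold lower number from compound 1 to compound 2 (0.35 log units; beyond the scatter). The two cores on which the change is made are not identical: compound 3 differs from compound 1 by 4-methylphenyl in place of 2-methylphenyl on an amide-type nitrogen, a change that gave a step of a 1.2-fold higher number from compound 1 to compound 3 (0.10 log units; within the scatter). The place of the methoxy is ortho to a large group in compound 2 but para to a large group in compound 4. The two changes are therefore the same kind of change rather than the same change. For completeness, the step from compound 2 to compound 3 is a 2.8-fold higher number from compound 2 to compound 3 (0.45 log units; beyond the scatter).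

Among the compounds with values here, on this basis compound 4 is expected to show a step of a 2.0-fold lower number from compound 3 to compound 4 (0.30 log units; within the scatter), resting on the single earlier step of a 2.2-fold lower number from compound 1 to compound 2 (0.35 log units; beyond the scatter) and on the near-equal values of compound 1 and compound 3. Within the data shown here, the estimate for compound 4 in this assay is 2600 nM, with a range from 1200 nM to 5600 nM that allows for the change of place and the single precedent.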

Compound 4, half-maximal inhibitory concentration: 6480 nM
Compound 4: the middle estimate sits 2.5-fold (0.40 log units) below what was measured; the measured number lies above the stated range.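

In this assay, within the data shown here, methoxy in place of methyl did not carry from one core to the other by the same amount: the same change on two cores in this assay, a 2.2-fold lower number (0.35 log units; beyond the scatter) from compound 1 to compound 2 and a 1.2-fold higher number (0.09 log units; within the scatter) from compound 3 to compound 4, 2.8-fold (0.44 log units) apart, beyond the scatter of two such steps On the core of compound 3 the change gave a 1.2-fold higher number from compound 3 to compound 4 (0.09 log units; within the scatter), so it produced no step that can be told from the scatter, while the change of the aryl group gave a 3.5-fold higher number from compound 2 to compound 4 (0.54 log units; beyond the scatter) and, with methyl also replaced, a 1.5-fold higher number from compound 1 to compound 4 (0.19 log units; within the scatter); the only clear separation involving the new compound is therefore the one from compound 2. This shows that the lower number reached with methoxy on the core of compound 1 cannot be taken as a general effect of methoxy in this series, but with one pair on each core it does not show what sets the two cores apart, nor how the change would behave on any further core.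

The compounds shown leave open whether a group other than methyl or methoxy on the aromatic ring, such as chlorine or a hydroxyl, would follow compound 2 or compound 4 in this assay. They also leave open whether a shorter or longer chain between the ester and the sulfur would keep these differences among the aryl groups.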